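Aryl imine series: 3-chlorophenyl replacing 4-hydroxyphenyl

The source may hold more compounds than are shown below. What is called first, only, known or untested is meant among the compounds shown, and "the series" means these compounds.

Measured so far:
Compound 1 `Cc1c(/N=C/c2ccccc2)c(=O)n(-c2ccccc2)n1C` gives 589000000 nM in a functional assay on HCT-116 cells (Homo sapiens) for cytotoxicity, read by MTT assay, with a stated time of 72 h; on this read-out lower numbers stand for stronger inhibition and higher numbers for weaker inhibition.
Compound 2 `Cc1c(/N=C/c2ccc(O)cc2)c(=O)n(-c2ccccc2)n1C` gives 646000000 nM in this assay.

Compound 2 cannot be told apart from compound 1 on these numbers: a 1.1-fold higher number from compound 1 to compound 2 (0.04 log units; within the scatter). Compound 3 `Cc1c(/N=C/c2cccc(Cl)c2)c(=O)n(-c2ccccc2)n1C` carries 3-chlorophenyl in place of 4-hydroxyphenyl on a carbon with a double bond to nitrogen. For the measured compounds named here, no measured step bears directly on this change; the only step on record, a hydroxy for hydrogen swap, stayed within the scatter. With nothing pointing either way, compound 3 is expected to sit close to compound 2, and the step from compound 2 to compound 3 is estimated as a 1.1-fold lower number from compound 2 to compound 3 (0.03 log units; within the scatter) in this assay. Compound 3 is therefore estimated at 600000000 nM, range 250000000 nM to 1400000000 nM.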

Compound 3, half-maximal inhibitory concentration: 912000000 nM
For compound 3 the middle estimate is 1.5-fold (0.18 log units) below the measured one; the measured number falls inside the stated range.
By their numbers in this assay, from the lowest: compounds 1, 2 and 3 (each within the scatter of the next).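

In this assay, 3-chlorophenyl in place of 4-hydroxyphenyl on a carbon with a double bond to nitrogen gives (a 1.4-fold higher number from compound 2 to compound 3 (0.15 log units; within the scatter)), and putting a chloro group on the unsubstituted ring gives (a 1.5-fold higher number from compound 1 to compound 3 (0.19 log units; within the scatter)). At this position, a chloro-bearing ring therefore cannot be told apart from either the hydroxy-bearing ring or the unsubstituted ring, even though the hydrogen-bond donor and acceptor counted on 4-hydroxyphenyl are absent from 3-chlorophenyl. No evidence on the cause is available. On these data alone, whether an amine or a carboxylic acid on this ring would give a number beyond the scatter remains open.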